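Exchanging methoxy for cyano on the ester chain of compound 1

This account rests on a few compounds, and the source may have more. Where it says the series, first, only, none or still open, it means among the compounds named here.

Compound 1 `COCCOC(=O)c1cc(N)c(Nc2ccc(C#N)cc2)cc1Oc1c(C)cc(/C=C/C#N)cc1C` carries a 2-methoxyethoxy ester on the shared core. In a physicochemical assay for lipophilicity, read by HPLC, measured as octanol-water partition, with a stated time of 24 h, at pH 7.4 (on this read-out lower numbers stand for lower lipophilicity and higher numbers for higher lipophilicity), compound 1 reaches only a limit, recorded as > 5, so its true position is known only as a limit; this is the point (the limit of > 5 in this assay, at which 1 of the 3 values shown sits). Compound 2 `Cc1cc(/C=C/C#N)cc(C)c1Oc1cc(Nc2ccc(C#N)cc2)c(N)cc1C(=O)NN` gives 2.31 and compound 3 `Cc1cc(/C=C/C#N)cc(C)c1Oc1cc(Nc2ccc(C#N)cc2)c(N)cc1C(N)=O` gives 3.53 in this assay. The measured steps replace the whole ester: a number at least 2.69 log units lower from compound 1 to compound 2 (beyond the scatter) and a number at least 1.47 log units lower from compound 1 to compound 3 (beyond the scatter), while a number 1.22 log units higher from compound 2 to compound 3 (beyond the scatter). Compound 4 `Cc1cc(/C=C/C#N)cc(C)c1Oc1cc(Nc2ccc(C#N)cc2)c(N)cc1C(=O)OCCC#N` differs from compound 1 only within the ester chain: cyano in place of methoxy on a saturated chain carbon, two bonds along the chain from an oxygen next to a carbonyl group. Among the measured compounds shown here, none of the measured steps keeps the ester, so they set no direct precedent for this smaller change; they show only that removing the ester entirely moves this assay by a large amount. Compound 4 is therefore expected to stay close to compound 1, with an estimated step of a number at least 0.10 log units lower from compound 1 to compound 4 (that floor lies within the scatter). Compound 4 is estimated at 4.9, within a range from 4.3 to 5.5, and it may itself come back as a limit.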

Compound 4, partition coefficient: > 5
Compound 4 ended at the assay's limit; the forecaster's own chance of this, stated with the estimate: 45%; middle value at least 0.10 log units away from the limit.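

Exchanging methoxy for cyano on the ester chain leaves compound 4 at the same limit of this assay as compound 1, and the step between them cannot be read: the limit of > 5 in this assay, at which 2 of the 4 values shown sit. Putting 2-cyanoethoxy in place of amino on the carbonyl carbon gives a number at least 1.47 log units higher from compound 3 to compound 4 (beyond the scatter) and putting it in place of aminoamino gives a number at least 2.69 log units higher from compound 2 to compound 4 (beyond the scatter) on this read-out. The large gap between the 2-methoxyethoxy ester and the two compounds without an ester therefore also holds for a second ester chain, and the cyano end does not bring compound 4 within the readable range.

The compounds shown leave open the size of the methoxy-to-cyano exchange itself. They also leave open whether a hydroxyl group, an amine or a shorter chain at this place would give a readable value.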